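A few compounds are considered here, and "the series" means these few. Any claim that something is new, unique, unknown or untested is made for them only; others in the source may bear on it.

Working notes on the series in a functional assay on THP-1 cells (Homo sapiens) for cytotoxicity, read by MTT assay, with a stated time of 24 h; on this read-out higher numbers stand for weaker inhibition and lower numbers for stronger inhibition. Compound 1 `C=C1CC[C@H]2C(C)(C)CCC[C@]2(C)[C@H]1CCC(C)CC(=O)O` gives > 200000 nM, which is a limit of the assay and not a number. Compound 3 `COc1ccc(/C=C2\CC[C@H]3C(C)(C)CCC[C@]3(C)[C@H]2CCC(C)CC(=O)O)cc1OC` gives 178000 nM. Among the compounds with values here, it stands level with compound 2 `CC(CC[C@H]1/C(=C/c2ccc([N+](=O)[O-])cc2)CC[C@H]2C(C)(C)CCC[C@]12C)CC(=O)O` at 180000 nM, the only other numeric reading so far.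

Compound 4 `CC(CC[C@H]1/C(=C/c2ccc(Br)cc2)CC[C@H]2C(C)(C)CCC[C@]12C)CC(=O)O` is the next analogue to be read, and its difference is 4-bromophenyl in place of 3,4-dimethoxyphenyl on a double-bonded chain carbon bound to a double-bonded ring carbon. In words, it has 4-bromophenyl in place of 3,4-dimethoxyphenyl on a double-bonded chain carbon bound to a double-bonded ring carbon.

Within the data shown here, one measured step bears on this change, since it falls at the same place: 3,4-dimethoxyphenyl in place of 4-nitrophenyl, which is a 1.0-fold lower number from compound 2 to compound 3 (0.00 log units; within the scatter). That step lies within the scatter, so exchanging these two groups left the reading unmoved. Among the measured compounds shown here, it is a single step, and it offers the only guide to how this place behaves in this assay. On that basis no step beyond the scatter is expected, in either direction, and the expected change is a 1.1-fold lower number from compound 3 to compound 4 (0.03 log units; within the scatter). A reading at the limit of the assay also remains possible. For compound 4 the estimated value is 165000 nM, with an expected range from 90000 nM to 250000 nM.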

Compound 4, half-maximal inhibitory concentration: > 200000 nM
Compound 4: no number, only a limit; the forecaster's own chance of this, stated with the estimate: 25%; middle value at least 1.2-fold (0.08 log units) from the limit.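

In this assay compound 4 gives > 200000 nM, which is a limit of the assay and not a number: the limit of > 200000 nM in this assay, at which 2 of the 4 values shown sit. The exchange at this place, on a double-bonded chain carbon bound to a double-bonded ring carbon, reads as an at least 1.1-fold higher number from compound 3 to compound 4 (0.05 log units; that floor lies within the scatter), and the exchange of bromo in place of nitro on an aromatic carbon reads as an at least 1.1-fold higher number from compound 2 to compound 4 (0.04 log units; that floor lies within the scatter); each is only a floor, so the true size of either step cannot be told. Within the data shown here, the earlier pair gave two numeric readings level with each other, whereas 4-bromophenyl is the first aromatic group at this place to give no number, so the level readings of 3,4-dimethoxyphenyl and 4-nitrophenyl cannot be extended to every aromatic group here.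

Going by these compounds, whether 4-bromophenyl truly moves the reading away from those two groups stays open, as a floor within the scatter fits both no change and a large one. Also open, on these data alone, is whether an amine or a hydroxyl on an aromatic carbon at this place would give a number beyond the scatter of those readings, in either direction.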